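Aryl exchange on compound 1 awaiting its measurement

The source may report more compounds than this note shows. Statements on the series, on what has been measured and on what is new or still open speak of the compounds shown alone.

In an assay on isolated protein (Bos taurus) for inhibition of geranylgeranyl transferase type-1 subunit beta (Homo sapiens) (on this read-out lower numbers stand for stronger inhibition and higher numbers for weaker inhibition), compound 1 `Cn1cncc1C(OCc1ccc(C#N)cc1-c1ccc(F)c(Cl)c1)c1ccc(C#N)nc1` gives 8600 nM, the highest of the three numbers in hand. Within the data shown here, compound 3 `Cn1cncc1C(OCc1ccc(C#N)nc1-c1cc(Cl)cc(Cl)c1)c1ccc(C#N)cc1` gives 1400 nM, and compound 2 `Cn1cncc1C(OCc1ccc(C#N)nc1N1CCN(C(=O)OC(C)(C)C)CC1)c1ccc(C#N)cc1` gives 42 nM; both gaps to compound 1 lie beyond the usual scatter, the one to compound 2 being the widest. Among the measured compounds shown here, compound 3 and compound 2 each differ from compound 1 in more than one place, so no single step toward them is isolated.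

Compound 4 `Cn1cncc1C(OCc1ccc(C#N)cc1-c1cccc(OC(F)(F)F)c1)c1ccc(C#N)nc1` is the unmeasured member. It differs from compound 1 by 3-(trifluoromethoxy)phenyl in place of 3-chloro-4-fluorophenyl on an aromatic carbon, ortho to a large group and meta to a cyano group. For the measured compounds named here, no measured pair in this set shares that change, so nothing in hand calibrates it. The expected step in this assay is a 1.4-fold lower number from compound 1 to compound 4 (0.16 log units; within the scatter), essentially none beyond the scatter, with at most a slight lean toward a lower number. Compound 4 is therefore estimated at 6000 nM, within 2000 nM to 20000 nM.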

Compound 4, half-maximal inhibitory concentration: 990 nM
Compound 4: the middle estimate sits 6.1-fold (0.78 log units) above what was measured; measured number below the stated range.
By their numbers in this assay, from the lowest: compound 2; then compounds 4 and 3 (each within the scatter of the next); then compound 1.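

In this assay, among these compounds, the aryl group on this aromatic carbon, ortho to a large group and meta to a cyano group, is not interchangeable: 3-(trifluoromethoxy)phenyl in place of 3-chloro-4-fluorophenyl gives an 8.7-fold lower number from compound 1 to compound 4 (0.94 log units; beyond the scatter) as the first single-place step. The step lies beyond the scatter even though a six-membered aromatic ring of carbon only both leaves and enters. Nothing in hand identifies what drives it.

The step changes the trifluoromethoxy group and the loss of both halogens together, so a phenyl carrying only a methoxy group or a lone chlorine would be needed to separate them. Compound 2 and compound 3 differ from compound 4 in more than one place, so whether this exchange holds on their cores cannot be read.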